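Furan regioisomer series: tert-butyl ester at the three-position

A few compounds are considered here, and "the series" means these few. Any claim that something is new, unique, unknown or untested is made for them only; others in the source may bear on it.

Measured so far:
compound 1 `CC1=C(C(=O)OCC(C)C)C(c2ccco2)NC(=O)N1C` gives 4%
compound 2 `CC1=C(C(=O)OC(C)(C)C)C(c2ccco2)NC(=O)N1C` gives 26%
compound 3 `CC1=C(C(=O)OCC(C)C)C(c2ccoc2)NC(=O)N1C` gives 1%

All three were tested in an assay on membranes from HEK293 cells for displacement of a labelled ligand from adenosine receptor A2b (Homo sapiens), read by scintillation counting, with a stated time of 30 min, tested at 1 uM; on this read-out lower numbers stand for less inhibition and higher numbers for more inhibition at the one concentration tested (going by the name of the read-out). The change from compound 1 to compound 2 is tert-butyl in place of isobutyl on an oxygen next to a carbonyl group and made a step of a number 22 percentage points higher from compound 1 to compound 2 (beyond the scatter). The two cores differ by furan-3-yl in place of furan-2-yl on a saturated ring carbon, which gave a step of a number 3 percentage points lower from compound 1 to compound 3 (within the scatter). Compound 4 `CC1=C(C(=O)OC(C)(C)C)C(c2ccoc2)NC(=O)N1C` has not been measured; it differs from compound 3 by tert-butyl in place of isobutyl on an oxygen next to a carbonyl group, with the same place as in compound 1 to compound 2, so this is the same change. For compound 4 a step of a number 15 percentage points higher from compound 3 to compound 4 (beyond the scatter) is expected in this assay, resting on compound 1 to compound 2 because of a number 22 percentage points higher from compound 1 to compound 2 (beyond the scatter), set against the low starting point of compound 3 at 1%. Compound 4 is estimated at 16%, between 4% and 32%.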

Compound 4, a percentage reported as inhibition, at one concentration (the size of the read-out at that concentration, not a potency): 16%
Compound 4: middle estimate and measured number agree at the digits printed, and the stated range covers the measured number.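

In this assay, tert-butyl in place of isobutyl on the ester oxygen also raises the number on the core of compound 3, giving a number 15 percentage points higher from compound 3 to compound 4 (beyond the scatter), and the step agrees with the earlier one: the same change on two cores in this assay, a number 22 percentage points higher (beyond the scatter) from compound 1 to compound 2 and a number 15 percentage points higher (beyond the scatter) from compound 3 to compound 4, 7 percentage points apart, within the scatter of two such steps Furan-3-yl in place of furan-2-yl gives a number 10 percentage points lower from compound 2 to compound 4 (within the scatter) on the tert-butyl ester, and this step likewise does not separate from its earlier counterpart: the same change on two cores in this assay, a number 3 percentage points lower (within the scatter) from compound 1 to compound 3 and a number 10 percentage points lower (within the scatter) from compound 2 to compound 4, 7 percentage points apart, within the scatter of two such steps This shows the ester change carrying across these two cores only; with just two pairs at one concentration, it does not show potency, a reason for the step or transfer to any other core.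

Still open, as far as these compounds go, is whether a longer chain on the ester oxygen would extend the step. Also open, from the compounds shown here alone, is how a carboxylic acid or an amide in place of the ester would read.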